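A few compounds are considered here, and "the series" means these few. Any claim that something is new, unique, unknown or untested is made for them only; others in the source may bear on it.

Compound 2 `Cn1cnnc1SCCc1nnc(SCC(=O)Nc2ccc(F)cc2)o1` was tested in an ADME assay on NIH3T3 cells (Mus musculus) for cytotoxicity, read by MTT assay, with a stated time of 24 h; on this read-out lower numbers stand for stronger inhibition and higher numbers for weaker inhibition. In that assay compound 2 reaches only the assay limit of > 500 ug/mL, so no exact number is known for it. Compound 1 `Cn1cnnc1SCCc1nnc(SCC(=O)Nc2ccc([N+](=O)[O-])cc2)o1` carries a nitro group where compound 2 carries a fluoro. In this assay compound 1 likewise stops at the limit of > 500 ug/mL. The step that the two limits leave unreadable from compound 1 to compound 2 therefore cannot be read, as both values sit at the limit of > 500 ug/mL in this assay, at which 2 of the 2 values shown sit. Compound 3 `Cn1cnnc1SCCc1nnc(SCC(=O)Nc2ccc(Cl)cc2)o1` is the next member: chloro in place of fluoro on an aromatic carbon. Within the data shown here, the only measured step bears on it merely by showing that a neighbouring change left no readable number, so no shift beyond the scatter is expected in this assay, in either direction. The step of a number no higher from compound 2 to compound 3 (the limit leaves the size open) is the estimate given here. For compound 3 the expected value in this assay is 500 ug/mL, with a range from 250 ug/mL to 1000 ug/mL, and most likely the assay will again report only its limit.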

Compound 3, half-maximal inhibitory concentration: > 500 ug/mL
Compound 3: only a limit was reported (the forecaster's own chance of this, stated with the estimate: 85%); the middle value sits exactly at the limit.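

Among these compounds, compound 3 also stops at the assay limit, so no step among compound 1, compound 2 and compound 3 can be read in this assay: the limit of > 500 ug/mL in this assay, at which 3 of the 3 values shown sit. The compounds shown leave open whether the nitro, fluoro and chloro compounds differ at all, and at what concentration any of them would inhibit the cells.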